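This account rests on a few compounds, and the source may have more. Where it says the series, first, only, none or still open, it means among the compounds named here.

Measured compounds:
compound 1 `Cn1c(-c2ccccc2)nc2c1c(=O)[nH]c(=O)n2C` — 3400 nM
compound 2 `Cn1c(=O)c2c(nc(-c3ccc(C(F)(F)F)cc3)n2C)n(C)c1=O` — 17000 nM
compound 3 `C=CCn1c(=O)c2c(nc(-c3ccccc3)n2C)n(C)c1=O` — 9000 nM

In an assay for binding affinity to adenosine receptor A1 (Rattus norvegicus), read by radioligand binding (on this read-out lower numbers stand for stronger inhibition and higher numbers for weaker inhibition), compound 3 stands second highest of the three values shown. Among the measured compounds shown here, its nearest neighbour is compound 2, whose value lies within the scatter of that of compound 3; its furthest is compound 1, and the single measured step, a 2.6-fold higher number from compound 1 to compound 3 (0.42 log units; beyond the scatter), lies beyond the scatter.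

Compound 4 `C=CCn1c(=O)c2c(nc(-c3ccc(C(F)(F)F)cc3)n2C)n(C)c1=O` differs from compound 3 in one place: trifluoromethyl in place of hydrogen on an aromatic carbon. For the measured compounds named here, no measured step bears directly on this change. Compounds 1 and 2 differ in the same way but also in a second place, so their values can only be read side by side: compound 1 gives 3400 nM and compound 2 gives 17000 nM, a higher number where the trifluoromethyl group is present. On that basis a modest weakening is expected for compound 4, with a 2.2-fold higher number from compound 3 to compound 4 (0.35 log units; beyond the scatter) as the estimated step. Compound 4 is therefore expected to give about 20000 nM in this assay, with a likely range from 7000 nM to 60000 nM.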

Compound 4, inhibition constant: 5700 nM
The estimate for compound 4 lay 3.5-fold (0.55 log units) above the measured number; measured number outside the range, below it.
By their numbers in this assay, from the lowest: compounds 1, 4, 3 and 2 (each within the scatter of the next, the first and the last beyond it).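

In this assay, among the compounds shown here, trifluoromethyl in place of hydrogen on an aromatic carbon, para to a large group, gives the first direct reading of this change: a 1.6-fold lower number from compound 3 to compound 4 (0.20 log units; within the scatter), so with the allyl group present the two values cannot be told apart. The second step isolates the chain on the aromatic nitrogen with trifluoromethyl held in place, and vinyl in place of hydrogen on that saturated chain carbon gives a 3.0-fold lower number from compound 2 to compound 4 (0.47 log units; beyond the scatter). Nothing shown here offers an explanation for either step.

From the compounds shown here alone, it remains open whether the trifluoromethyl result would hold with hydrogen or methyl on that nitrogen rather than allyl. Going by these compounds, how a nitrile or an amine at the same aromatic carbon, or a longer chain in place of allyl, would read in this assay also stays unknown.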